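From tert-butyl to hexyl: a half-life behind limits

The source may hold more compounds than are shown below. What is called first, only, known or untested is meant among the compounds shown, and "the series" means these compounds.

Compound 1 `C=CCON/C(=N\C1=NC(=O)C(=O)N1C(C)C)Nc1ccc(Cl)c(Cl)c1` gives > 1 h (a limit)
Compound 2 `CC(C)N1C(=O)C(=O)N=C1/N=C(\NOCc1ccccc1)Nc1ccc(Cl)c(Cl)c1` gives > 1 h (a limit)
Compound 3 `CC(C)N1C(=O)C(=O)N=C1/N=C(/Nc1ccc(Cl)c(Cl)c1)NC(C)(C)C` gives > 1 h (a limit)

In an in vitro ADME assay on microsomes from liver (Mus musculus) for metabolic stability, read by LC-MS (a higher number here means that the compound lasts longer, a lower number that the compound disappears faster), compound 3 stands at > 1 h, which is a limit and not a number. Compound 4 `CCCCCCN/C(=N\C1=NC(=O)C(=O)N1C(C)C)Nc1ccc(Cl)c(Cl)c1` carries hexyl in place of tert-butyl on an amine nitrogen. Two measured steps also change the group on this amine nitrogen: a step that the two limits leave unreadable from compound 1 to compound 3 and a step that the two limits leave unreadable from compound 2 to compound 3. Neither has a readable size, and (the limit of > 1 h in this assay, at which 3 of the 3 values shown sit). They therefore point in no direction, and no step beyond the scatter is expected in this assay. The expected change is a number no higher from compound 3 to compound 4 (the limit leaves the size open). The estimated half-life of compound 4 is 1 h, with an expected range from 0.4 h to 2.5 h.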

Compound 4, half-life: 0.579 h
Compound 4: middle estimate off by 1.7-fold (0.24 log units), on the high side; low and high end bracket the measured number.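

For the compounds shown here, compound 4 gives the first true number at this amine nitrogen in this assay, while the other compounds stop at a limit: the limit of > 1 h in this assay, at which 3 of the 4 values shown sit. The steps among those three limits cannot be read, but hexyl now gives an at least 1.7-fold lower number from compound 3 to compound 4 (0.23 log units; that floor lies within the scatter), an at least 1.7-fold lower number from compound 2 to compound 4 (0.23 log units; that floor lies within the scatter) and an at least 1.7-fold lower number from compound 1 to compound 4 (0.23 log units; that floor lies within the scatter). As far as these compounds go, each is only a floor, so the true size of each step stays unknown.

Whether a shorter chain such as butyl would also give a number is open. So is how a longer chain such as octyl would compare with hexyl.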